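The source may hold more compounds than are shown below. What is called first, only, known or untested is meant among the compounds shown, and "the series" means these compounds.

Of the compounds shown here, two have been tested so far in an ADME assay on HEK-293T cells (Homo sapiens) for cytotoxicity, read by luminescence, with a stated time of 24 h; a lower number here means that less compound is tolerated, a higher number that more compound is tolerated. Compound 1 `COc1ccc(Cn2c(C(=O)NCc3ccccc3)cc3sccc32)cc1` gives > 100000 nM, which is a limit of the assay and not a number. Compound 2 `COc1ccc(Cn2c(C(=O)N3CCC(C(=O)NCc4ccccc4)CC3)cc3sccc32)cc1` gives > 100000 nM, again a limit and not a number. Compound 2 therefore has no exact value, and the only other result is no more exact: the limit of > 100000 nM in this assay, at which 2 of the 2 values shown sit.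

Compound 3 `COc1ccc(Cn2c(C(=O)N3CCC(C(=O)NCCC(C)C)CC3)cc3sccc32)cc1` keeps the core of compound 2 and differs in one place: isobutyl in place of phenyl on a saturated chain carbon bound to an amide-type nitrogen. In words, isobutyl stands in place of phenyl on a saturated chain carbon bound to an amide-type nitrogen, which can also be read as benzylcarbamoyl changing to isopentylcarbamoyl.

Going by the values given here, no pair of measured compounds shows what this kind of swap does in this assay, so the expectation is cautious: no change beyond the usual scatter, in either direction. The estimate amounts to a number no higher from compound 2 to compound 3 (the limit leaves the size open). For compound 3 the expected half-maximal cytotoxic concentration is 100000 nM, within an estimated range from 50000 nM to 200000 nM. The result may well turn out to be another limit.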

Compound 3, half-maximal cytotoxic concentration: 30900 nM
Compound 3: the middle estimate sits 3.2-fold (0.51 log units) above what was measured, outside the stated range (below it).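

The swap at this position has a visible effect: in this assay, isobutyl in place of phenyl on a saturated chain carbon bound to an amide-type nitrogen gives an at least 3.2-fold lower number from compound 2 to compound 3 (0.51 log units; beyond the scatter). The end of this side chain therefore matters for how much compound the cells tolerate, and the change lies beyond the usual scatter, something the earlier results could not show while both sat at the same limit. Going by these compounds alone, compound 3 also provides the first exact value, but the full size of the step remains unknown because compound 2 has only a limit and not a number: the limit of > 100000 nM in this assay, at which 2 of the 3 values shown sit.

A single swap cannot separate the loss of the aromatic ring from the change in the shape of the group that replaces it, since benzyl and isopentyl differ in both ways. As far as these compounds go, whether a cyclohexylmethyl group, which keeps a ring without aromatic character, would behave like benzyl or like isopentyl remains open, as does the effect of a longer chain or of a chain ending in an amine or a carboxylic acid.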